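Swapping the Oxadiazole Attachment Point in a Clearance Series

The source may hold more compounds than are shown below. What is called first, only, known or untested is meant among the compounds shown, and "the series" means these compounds.

Three compounds on a shared core have been run in an in vivo ADME assay on the whole organism (strain Sprague-Dawley) for pharmacokinetics, with Rattus norvegicus as the target, at a dose of 2 mg/kg by the intravenous route; a lower number here means slower removal, a higher number faster removal of the compound. Compound 1 `C[C@@H](Nc1nccc(Cl)c1NC(=O)CC#N)c1ccc(-c2cccc(F)c2C#N)cc1` gives 8.3 mL/min/kg in this assay. Compound 2 `Cc1noc(-c2c(F)cccc2-c2ccc([C@@H](C)Nc3nccc(Cl)c3NC(=O)CC#N)cc2)n1` gives 9.5 mL/min/kg. Compound 3 `COC(=O)c1c(Cl)cccc1-c1ccc([C@@H](C)Nc2nccc(Cl)c2NC(=O)CC#N)cc1` gives 24 mL/min/kg. Among these three numbers compound 2 stands second highest: it sits within the scatter of compound 1, and beyond the scatter of compound 3, which has the highest number.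

Two measured steps connect these compounds. The step of a 1.1-fold higher number from compound 1 to compound 2 (0.06 log units; within the scatter), putting 3-methyl-1,2,4-oxadiazol-5-yl in place of cyano on an aromatic carbon, left the number unchanged within the scatter. The step of a 2.9-fold higher number from compound 1 to compound 3 (0.46 log units; beyond the scatter), putting 3-chloro-2-(methoxycarbonyl)phenyl in place of 2-cyano-3-fluorophenyl on an aromatic carbon, was a modest rise.

Compound 4 `Cc1nc(-c2c(F)cccc2-c2ccc([C@@H](C)Nc3nccc(Cl)c3NC(=O)CC#N)cc2)no1` has not yet been measured. It differs from compound 2 by 5-methyl-1,2,4-oxadiazol-3-yl in place of 3-methyl-1,2,4-oxadiazol-5-yl on an aromatic carbon, the same atoms joined differently. Among the measured compounds shown here, only the step from compound 1 to compound 2 touches this position, and it stayed within the scatter, so no step beyond the scatter is expected here either; the expected step is a 1.1-fold higher number from compound 2 to compound 4 (0.02 log units; within the scatter). Compound 4 is therefore estimated at 10 mL/min/kg in this assay, with a range from 6 mL/min/kg to 17 mL/min/kg.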

Compound 4, clearance: 4.9 mL/min/kg
Compound 4: middle estimate off by 2.0-fold (0.31 log units), on the high side; measured number below the stated range.
By their numbers in this assay, from the lowest: compounds 4, 1 and 2 (each within the scatter of the next); then compound 3.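

At this position, on an aromatic carbon ortho to a fluoro group, joining the same atoms differently gave a 1.9-fold lower number from compound 2 to compound 4 (0.29 log units; within the scatter) in this assay, so the two methyl-oxadiazole arrangements cannot be told apart in this read-out. Placing 5-methyl-1,2,4-oxadiazol-3-yl where the cyano group stands gave a 1.7-fold lower number from compound 1 to compound 4 (0.23 log units; within the scatter), so compounds 1, 2 and 4 now form a set of three different groups at this carbon, all within the scatter of one another. No supporting data are available to account for these results, and the small differences among the three do not call for an explanation of their own.

The only step beyond the scatter remains a 2.9-fold higher number from compound 1 to compound 3 (0.46 log units; beyond the scatter), and it exchanges the whole substituted phenyl, so the compounds shown do not separate the contribution of the methoxycarbonyl group from that of the chloro group. From the compounds shown here alone, it remains open whether a carboxylic acid, a primary amide or an aminomethyl group on this same carbon, with the fluoro group kept, would stay within the scatter of compound 1 or move beyond it.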